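A Hydroxy Group Joins the Fluorophenyl of Compound 1

The source may hold more compounds than are shown below. What is called first, only, known or untested is meant among the compounds shown, and "the series" means these compounds.

The measured compounds:
compound 1, `Cc1c(C(=O)N/N=C\c2ccccc2F)oc2cccc(O)c12`: >= 40000 nM
compound 2, `Cc1c(C(=O)N/N=C\c2ccc(O)cc2)oc2cccc(O)c12`: 21700 nM
compound 3, `Cc1c(C(=O)N/N=C\c2cccc(O)c2)oc2cccc(O)c12`: 17600 nM

In a functional assay on PC-3 cells (Homo sapiens) for inhibition (a higher number here means a weaker inhibitor, a lower number a stronger inhibitor), compound 1 stands only at a limit of the assay, not at a number, namely (the limit of >= 40000 nM in this assay, at which 1 of the 3 values shown sits). Compound 4, `Cc1c(C(=O)N/N=C\c2cc(F)ccc2O)oc2cccc(O)c12`, has not been measured; it differs from compound 1 by 5-fluoro-2-hydroxyphenyl in place of 2-fluorophenyl on a carbon with a double bond to nitrogen. The two measured steps starting from compound 1 are the guides: an at least 1.8-fold lower number from compound 1 to compound 2 (0.26 log units; that floor lies within the scatter) and an at least 2.2-fold lower number from compound 1 to compound 3 (0.35 log units; beyond the scatter). Both lowered the number modestly, and a change of similar size and direction is expected here, with the caveat that compound 1 is itself only a limit. Compound 4 is expected at 28000 nM, within 12000 nM to 60000 nM. That expectation corresponds to an at least 1.4-fold lower number from compound 1 to compound 4 (0.15 log units; that floor lies within the scatter).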

Compound 4, half-maximal inhibitory concentration: 3170 nM
The estimate for compound 4 lay 8.8-fold (0.95 log units) above the measured number; the whole stated range lies above it.
By their numbers in this assay, from the lowest: compound 4; then compounds 3 and 2 (each within the scatter of the next). At a limit, above all of these: compound 1.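

Swapping in 5-fluoro-2-hydroxyphenyl on the carbon with a double bond to nitrogen gives what neither earlier hydroxyphenyl group gave, a clear separation from the other hydroxyphenyl compounds in this assay: a 5.6-fold lower number from compound 3 to compound 4 (0.74 log units; beyond the scatter), and a 6.8-fold lower number from compound 2 to compound 4 (0.84 log units; beyond the scatter). So carrying a hydroxy group is not enough on its own; the particular ring substitution matters at this position. The remaining step is an at least 12-fold lower number from compound 1 to compound 4 (1.10 log units; beyond the scatter), but it starts from a limit, so its size is only a floor: the limit of >= 40000 nM in this assay, at which 1 of the 4 values shown sits.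

Still open, from the compounds shown here alone, is whether the gain depends on the fluorine, the hydroxy placement or both. A plain 2-hydroxyphenyl would help separate these, and a 5-fluoro-2-aminophenyl would show whether an amine can replace the hydroxy group.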